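From Carbamate to Cyclobutylmethyl: One Substituent Change Awaits Measurement

The compounds below may be only part of what the source reports. "The series", "measured", "known", "first", "only" and "open" are said of these compounds alone.

Compound 1 `CC(C)(C)OC(=O)N1CCC(O[C@H]2CC[C@H](Oc3ccc(S(C)(=O)=O)cn3)CC2)CC1`: in a functional assay on isolated protein for agonist activity at Glucose-dependent insulinotropic receptor (Homo sapiens), read by HTRF and cAMP accumulation (a lower number here means a smaller maximal response, a higher number a larger maximal response), compound 1 gives 111%.
Compound 2 `CC(C)(C)OC(=O)N1CCC(O[C@H]2CC[C@H](Oc3cnc(S(C)(=O)=O)cn3)CC2)CC1`: in this assay compound 2 gives 110%.
Compound 3 `CC(C)(C)OC(=O)N1CCC(O[C@H]2CC[C@H](Oc3cnc(C#N)cn3)CC2)CC1`: in this assay compound 3 gives 110%.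

The three measured compounds share one core and differ only in the aromatic group on the oxygen on a saturated carbon. Every step among them is small: a number 1 percentage points lower from compound 1 to compound 2 (within the scatter), a number 1 percentage points lower from compound 1 to compound 3 (within the scatter) and no change at the digits printed from compound 2 to compound 3 (within the scatter). Compound 2 stands level with compound 3 at the digits given, and its gap to compound 1 is within the scatter.

Compound 4 `CS(=O)(=O)c1cnc(O[C@H]2CC[C@H](OC3CCN(CC4(C(F)(F)F)CCC4)CC3)CC2)cn1` differs from compound 2 at the other end of the molecule: (1-(trifluoromethyl)cyclobutyl)methyl in place of tert-butoxycarbonyl on an amine nitrogen in a ring. For the measured compounds named here, no measured step touches this position; all three concern the aromatic group on the oxygen, and all lie within the scatter. Going by the values given here, there is thus no measured step that bears on the change to compound 4, and the expectation rests only on the narrow spread of the three values. The expected step is a number 5 percentage points lower from compound 2 to compound 4 (within the scatter), none beyond the scatter. Compound 4 is therefore estimated to give 105% in this assay, with a range from 85% to 120%.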

Compound 4, largest response reached (Emax), in percent of the reference or control that the assay uses: 96%
Beside the measured number, compound 4's estimate is 9 percentage points above it; low and high end bracket the measured number.
By their numbers in this assay, from the lowest: compound 4; then compounds 2, 3 and 1 (each within the scatter of the next).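

In this assay the exchange of tert-butoxycarbonyl for (1-(trifluoromethyl)cyclobutyl)methyl on the amine nitrogen in a ring gives a number 14 percentage points lower from compound 2 to compound 4 (beyond the scatter), the only step shown that lies beyond the scatter. Among these compounds, then, the maximal response shifts measurably with the group on this nitrogen, whereas the three exchanges of the aromatic group on the oxygen all stayed within the scatter. Nothing given here accounts for the size or direction of this step.

The compounds shown leave open whether a plain cyclobutylmethyl group, without the trifluoromethyl, would give a similar number on this nitrogen. On these data alone, it also remains open whether the same exchange would give a comparable step with 5-cyanopyrazin-2-yl or 5-(methylsulfonyl)pyridin-2-yl on the oxygen.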